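Compound 4: 4-hydroxyphenyl in place of benzyl

The source may report more compounds than this note shows. Statements on the series, on what has been measured and on what is new or still open speak of the compounds shown alone.

Measured so far in a physicochemical assay for lipophilicity, read by HPLC (a lower number here means a more polar compound, a higher number a more lipophilic compound), for three compounds:
- compound 1 `Nc1ccccc1NC(=O)c1ccc(CSC2=N[C@@H](Cc3ccccc3)CO2)cc1` gives 5.41
- compound 2 `Nc1ccccc1NC(=O)c1ccc(CNC2=N[C@@H](Cc3ccccc3)CO2)cc1` gives 2.86
- compound 3 `Nc1ccccc1NC(=O)c1ccc(CNC2=NC(c3ccc(F)cc3)CO2)cc1` gives 3.39

Compound 2 holds the lowest of the three numbers in this assay and so marks the polar end of the set so far. Compound 3 stands above it by a gap beyond the scatter. Compound 1 stands furthest above it, again beyond the scatter.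

The next compound to be read is compound 4 `Nc1ccccc1NC(=O)c1ccc(CNC2=N[C@@H](c3ccc(O)cc3)CO2)cc1` and it has no number yet. Against compound 2 the change is 4-hydroxyphenyl in place of benzyl on a saturated ring carbon and in words it is 4-hydroxyphenyl in place of benzyl on a saturated ring carbon, next to the ring nitrogen.

For the measured compounds named here, no pair of measured compounds isolates this exchange, and no measured compound carries the 4-hydroxyphenyl group, so the size of the step is a judgement and the range is kept wide. The starting point is compound 2 at 2.86 in this series.

The expected step in this assay is downward and beyond the scatter, estimated as a number 0.56 log units lower from compound 2 to compound 4 (beyond the scatter) for this exchange.

For compound 4 the estimated value is 2.3 with an expected range from 1.8 to 2.8 in this measurement.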

Compound 4, distribution coefficient: 1.74
Estimate against measurement, compound 4: 0.56 log units above; the whole stated range lies above it.
By their numbers in this assay, from the lowest: compound 4; then compound 2; then compound 3; then compound 1.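

In this assay, for the compounds shown here, the exchange of benzyl for 4-hydroxyphenyl on a saturated ring carbon, next to the ring nitrogen, gives a number 1.12 log units lower from compound 2 to compound 4 (beyond the scatter) as a large step, and this is the only reading at this position between compounds that differ in one place. Both groups count 7 heavy atoms and one six-membered aromatic ring of carbon only, so by these counts the size of the group stays level, while the entering group carries 1 hydrogen-bond donor and 1 hydrogen-bond acceptor and the leaving group carries neither. Compound 4 now holds the lowest number of the four, and nothing measured here accounts for the size of the step.

The exchange alters two things at once, the carbon link of benzyl and the hydroxyl on the aromatic ring, and a plain phenyl group at this position would be needed to read the share of each. On these data alone, whether an amine or a carboxylic acid in place of the hydroxyl would move the number the same way or as far stays open, as does the size of this exchange on the core of compound 1.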